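From 3-methylphenyl to 4-fluorophenyl on compound 3

The compounds below may be only part of what the source reports. "The series", "measured", "known", "first", "only" and "open" are said of these compounds alone.

Compound 1 `COc1ccccc1Oc1c(N)nc(-c2ccccc2)nc1Cl` gives 4610 nM
Compound 2 `COc1ccccc1Oc1c(N)nc(-c2cccc(C)c2)nc1Cl` gives 13100 nM
Compound 3 `COc1ccccc1Oc1c(N)nc(-c2cccc(C)c2)nc1OCCO` gives 70900 nM

In a functional assay on B16 cells (Mus musculus) for cytotoxicity, read by CCK-8 assay, with a stated time of 24 h (on this read-out higher numbers stand for weaker inhibition and lower numbers for stronger inhibition), compound 3 stands highest of the three at 70900 nM and so marks the weak end of this small set. Compound 4 `COc1ccccc1Oc1c(N)nc(-c2ccc(F)cc2)nc1OCCO` keeps the 2-hydroxyethoxy group but carries 4-fluorophenyl in place of 3-methylphenyl on an aromatic carbon on the aromatic carbon between two ring nitrogen atoms. Among the compounds with values here, one measured step touches that methyl, namely a 2.8-fold higher number from compound 1 to compound 2 (0.45 log units; beyond the scatter) when methyl replaced hydrogen on an aromatic carbon, and read backwards it points to a lower number once the methyl is gone. The other step, a 5.4-fold higher number from compound 2 to compound 3 (0.73 log units; beyond the scatter) for 2-hydroxyethoxy in place of chloro, concerns a group that compound 3 and compound 4 share, so it sets the high starting level without bearing on the swap. Within the data shown here, no measured compound carries 4-fluorophenyl, so the range stays wide. A modest move toward a lower number is expected, an estimated 2.0-fold lower number from compound 3 to compound 4 (0.31 log units; beyond the scatter) in this assay overall. For compound 4 the estimated value is 35000 nM with 12000 nM to 90000 nM as the expected span of that estimate.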

Compound 4, half-maximal inhibitory concentration: 30100 nM
The estimate for compound 4 lay 1.2-fold (0.07 log units) above the measured number; the range from low to high includes it.
By their numbers in this assay, from the lowest: compound 1; then compound 2; then compound 4; then compound 3.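

In this assay, the group on the aromatic carbon between two ring nitrogen atoms still matters when the 2-hydroxyethoxy group is in place: 4-fluorophenyl in place of 3-methylphenyl gives a 2.4-fold lower number from compound 3 to compound 4 (0.37 log units; beyond the scatter). Until now this position had been varied only in the chloro compounds, with a 2.8-fold higher number from compound 1 to compound 2 (0.45 log units; beyond the scatter), so the result extends its effect to a second setting and adds the first ring that carries fluorine, with the number moving down. No data shown here offer an explanation for this step.

The swap removes a methyl group and adds a fluorine atom at once, and the compounds shown do not divide the step between those two changes. Also open, on these data alone, is how this position would respond to 4-chlorophenyl, or to an amine or a longer chain in place of the 2-hydroxyethoxy group.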